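Swapping Methoxy for Hydrogen on Compound 2

A few compounds are considered here, and "the series" means these few. Any claim that something is new, unique, unknown or untested is made for them only; others in the source may bear on it.

In a functional assay on HT-29 cells (Homo sapiens) for inhibition, read by sulforhodamine B assay, with a stated time of 48 h, tested at 10 uM (a lower number here means less inhibition of growth, a higher number more inhibition of growth at the concentration tested), compound 1 (`C/C(=N\O)c1ccc(NC(=O)Cn2nc(-c3ccc(Cl)cc3)nc2N)cc1`) reaches 13.3% and compound 2 (`COc1ccc(-c2nc3sc(-c4ccccc4)cn3n2)cc1`) reaches 70% as the higher of these two numbers, a gap beyond the usual scatter. Compound 3 (`c1ccc(-c2nc3sc(-c4ccccc4)cn3n2)cc1`) keeps the core of compound 2 and differs in one place, with hydrogen in place of methoxy on an aromatic carbon. For the measured compounds named here, no measured pair of compounds shows this change, and compound 1 is too different in structure to guide it. The expectation therefore starts from compound 2 at 70% as the closest measured neighbour. A moderate fall, only a little beyond the scatter, seems most likely: the expected step is a number 15 percentage points lower from compound 2 to compound 3 (beyond the scatter) in this estimate. The expected value for compound 3 is 55% (from 30% to 80%).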

Compound 3, percent growth inhibition at one concentration: 9%
Beside the measured number, compound 3's estimate is 46 percentage points above it; measured number outside the range, below it.
By their numbers in this assay, from the lowest: compounds 3 and 1 (each within the scatter of the next); then compound 2.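

In this assay, putting hydrogen where the methoxy stood gives a number 61 percentage points lower from compound 2 to compound 3 (beyond the scatter), a large step. For the compounds shown here, this is the first comparison here of two compounds that differ in one place only, and it shows that growth inhibition at the tested concentration depends strongly on what sits on this aromatic carbon, para to a large group. The measurements and structures shown give no explanation for the size of this step.

A hydroxyl, an ethoxy group, a chlorine atom or an amine at the same place would help separate a specific need for methoxy from a more general need for some group other than hydrogen, but none of these is among the compounds shown. As far as these compounds go, whether the same swap would have a similar effect on another core also remains open.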